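This account rests on a few compounds, and the source may have more. Where it says the series, first, only, none or still open, it means among the compounds named here.

Three analogues share one core and differ only in the group on an aromatic nitrogen. Compound 1 `Cc1cc(NC(=O)Cn2nnc(-c3ccccc3)n2)n(C2CCCCC2)n1` carries cyclohexyl there, and in an ADME assay on microsomes from liver (Mus musculus) for metabolic stability (a higher number here means faster removal of the compound, a lower number slower removal), compound 1 gives 2920 mL/min/kg. Compound 2 `Cc1cc(NC(=O)Cn2nnc(-c3ccccc3)n2)n(C2CCC(F)(F)CC2)n1` carries 4,4-difluorocyclohexyl, and in this assay compound 2 gives 723 mL/min/kg. Compound 3 `Cc1cc(NC(=O)Cn2nnc(-c3ccccc3)n2)n(C2CCS(=O)(=O)C2)n1` carries 1,1-dioxothiolan-3-yl. In this assay compound 3 gives only a limit, < 49.5 mL/min/kg, which is the limit of < 49.5 mL/min/kg in this assay, at which 1 of the 3 values shown sits. Across the three, a 4.0-fold lower number from compound 1 to compound 2 (0.61 log units; beyond the scatter) was a modest step, whereas an at least 58-fold lower number from compound 1 to compound 3 (1.77 log units; beyond the scatter) and an at least 14-fold lower number from compound 2 to compound 3 (1.16 log units; beyond the scatter) were large, so compound 3 stands at the low end of the series, its number known only as a limit. Compound 4 `Cc1cc(NC(=O)Cn2nnc(-c3ccccc3)n2)n(CC2CCCCC2)n1` has not yet been measured; it differs from compound 3 by cyclohexylmethyl in place of 1,1-dioxothiolan-3-yl on an aromatic nitrogen. This change returns to a carbocycle much like that of compound 1, and both steps that exchanged a carbocycle for the dioxothiolane were large and downward, so a large step in the opposite direction is expected in this assay. That expectation amounts to an at least 50-fold higher number from compound 3 to compound 4 (1.70 log units; beyond the scatter). Compound 4 is therefore estimated to give about 2500 mL/min/kg, with a range from 800 mL/min/kg to 7000 mL/min/kg.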

Compound 4, clearance: > 5930 mL/min/kg
Compound 4 gave a limit, no number; the forecaster's own chance of this, stated with the estimate: 5%; middle value at least 2.3-fold (0.37 log units) away from the limit.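

Within the data shown here, compound 4 shows that this position can carry the number upward as well as downward: cyclohexylmethyl in place of 1,1-dioxothiolan-3-yl gives an at least 110-fold higher number from compound 3 to compound 4 (2.07 log units; beyond the scatter), the widest step so far. The same group gives an at least 8.2-fold higher number from compound 2 to compound 4 (0.91 log units; beyond the scatter), while against cyclohexyl it gives an at least 2.0-fold higher number from compound 1 to compound 4 (0.30 log units; that floor lies within the scatter), so any difference between cyclohexylmethyl and cyclohexyl cannot be established. Compound 4 stands at a limit rather than a number in this assay: the limit of > 5930 mL/min/kg in this assay, at which 1 of the 4 values shown sits.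

The compounds shown leave open how much of the low limit of compound 3 belongs to its two oxygens on sulfur and how much to its five-membered ring. They also leave open whether an amine or a hydroxyl group on the cyclohexylmethyl ring would bring the number down.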